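Compound 3: methoxy in place of chloro

The compounds below may be only part of what the source reports. "The series", "measured", "known", "first", "only" and "open" are said of these compounds alone.

In a functional assay on U-373MG ATCC cells (Homo sapiens) for inhibition, read by MTT assay, with a stated time of 72 h (a higher number here means a weaker inhibitor, a lower number a stronger inhibitor), compound 1 `CC1(C)CC(NC(=S)Nc2cccc(C#N)c2)c2cc(Br)ccc2O1` gives 6000 nM. Going by the values given here, in the same measurement compound 2 `CC1(C)CC(NC(=S)Nc2cccc(Cl)c2)c2cc(Br)ccc2O1` gives 8000 nM, which places it within the scatter of compound 1, its only measured neighbour, so the two cannot be ranked.

Compound 3 `COc1cccc(NC(=S)NC2CC(C)(C)Oc3ccc(Br)cc32)c1` has not yet been measured. It differs from compound 2 in carrying 3-methoxyphenyl instead of 3-chlorophenyl: methoxy in place of chloro on an aromatic carbon. The change lies on an aromatic carbon, meta to a large group.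

Among the compounds with values here, one measured step bears on it, chloro in place of cyano on an aromatic carbon: a 1.3-fold higher number from compound 1 to compound 2 (0.12 log units; within the scatter). Within the data shown here, this single pair establishes no trend, and no measured compound carries methoxy, so the evidence for compound 3 is thin. Among the measured compounds shown here, with only that small step as a guide, no change beyond the scatter is expected in this assay, although a larger one cannot be excluded.

The estimate amounts to an expected 1.1-fold lower number from compound 2 to compound 3 (0.06 log units; within the scatter).

For compound 3 the estimated value is 7000 nM, with an expected range of 3000 nM to 16000 nM.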

Compound 3, half-maximal inhibitory concentration: 66000 nM
Beside the measured number, compound 3's estimate is 9.4-fold (0.97 log units) below it; the measured number lies above the stated range.
By their numbers in this assay, from the lowest: compounds 1 and 2 (each within the scatter of the next); then compound 3.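

In this assay, this position, on an aromatic carbon meta to a large group, does respond to what it carries: cyano and chloro could not be ranked, but the exchange for methoxy gives an 8.3-fold higher number from compound 2 to compound 3 (0.92 log units; beyond the scatter) and, against the nitrile, an 11-fold higher number from compound 1 to compound 3 (1.04 log units; beyond the scatter) as well. Inhibition therefore weakens with methoxy relative to both other groups, and the insensitivity suggested by the earlier pair does not extend to all groups at this position. The chloro to methoxy exchange replaces one chlorine with a carbon and an oxygen and introduces a hydrogen-bond acceptor, but nothing available ties the weaker inhibition to any of these differences or to any other feature of the change.

From the compounds shown here alone, it remains open whether the weakening is particular to methoxy or extends to related groups such as hydroxy or the longer ethoxy, and whether an amine or a carboxylic acid here would track with methoxy or with chloro and cyano. Going by these compounds, it is also open whether methoxy has the same consequence on other carbons of this aromatic ring, or with a group other than bromo on the shared core.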